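Chlorophenyl for methoxyphenyl on a thiocarbonyl-bearing nitrogen

The source may report more compounds than this note shows. Statements on the series, on what has been measured and on what is new or still open speak of the compounds shown alone.

This account follows compound 1, with the structure `COc1cccc(NC(=S)NC2CC(C)(C)Oc3ccc(Br)cc32)c1`, toward compound 4, with the structure `CC1(C)CC(NC(=S)Nc2ccc(Cl)cc2)c2cc(Br)ccc2O1`. The activity of interest is a functional assay on B16-F10 cells (Mus musculus) for inhibition, read by MTT assay, with a stated time of 72 h; a lower number here means a stronger inhibitor, a higher number a weaker inhibitor. Compound 1 has no single number there: its result is recorded as "not determined" (no result reported). Two further compounds share the core of compound 1. Compound 2, with the structure `CC1(C)CC(NC(=S)Nc2ccc([N+](=O)[O-])cc2)c2cc(Cl)ccc2O1`, gives 3000 nM in this assay. Compound 3, with the structure `CC1(C)CC(NC(=O)Nc2ccccc2Cl)c2cc(F)ccc2O1`, has no result in this assay and stands at "not determined" (no result reported).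

The change from compound 1 to compound 4 is a single one: 4-chlorophenyl in place of 3-methoxyphenyl on an amide-type nitrogen. What leaves is the 3-methoxyphenyl group and what enters is the 4-chlorophenyl group, at the amide-type nitrogen whose other neighbour is the thiocarbonyl carbon.

Within the data shown here, no step between measured compounds is available for this change, and compound 1 itself has no number, so the size and direction of the step cannot be read from the data; the expectation rests on compound 2 alone. Compound 4 is expected to lie near compound 2 because compound 2 gives 3000 nM in this assay. The estimate for compound 4 in this assay is 3000 nM, with a range from 800 nM to 12000 nM.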

Compound 4, half-maximal inhibitory concentration: 7000 nM
Compound 4: middle estimate off by 2.3-fold (0.37 log units), on the low side; low and high end bracket the measured number.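

In this assay compound 1 stands at "not determined" (no result reported) and compound 4 gives 7000 nM, so no new step can be read between them. The compounds shown leave open how 4-chlorophenyl in place of 3-methoxyphenyl alters activity on the shared core. No available evidence bears on the result for compound 4.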